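Methyl for hydrogen at two places on a carbamate series

The source may report more compounds than this note shows. Statements on the series, on what has been measured and on what is new or still open speak of the compounds shown alone.

Measured so far:
compound 1, `COC(=O)N(C)CC#CCN1CCCC1`: > 10 mg/kg
compound 2, `COC(=O)N(C)CC#CCn1cncc1C`: 3 mg/kg
compound 3, `COC(=O)N(C)C(C)C#CCn1cncc1C`: 3.7 mg/kg

The three measured compounds were tested in a functional assay on the whole organism for antagonist activity, with Mus musculus as the target; on this read-out higher numbers stand for an effect only at larger amounts of compound and lower numbers for an effect already at smaller amounts. Compound 1 gives only a limit of the assay, > 10 mg/kg; this is the case described by the limit of > 10 mg/kg in this assay, at which 1 of the 3 values shown sits. How the core of compound 1 differs from that of compound 2 is not broken down here. Compound 2 gives 3 mg/kg in this assay, and compound 3, which carries methyl in place of hydrogen on a saturated chain carbon bound to an amide-type nitrogen and a triple-bonded carbon, gives 3.7 mg/kg. The step between them, a 1.2-fold higher number from compound 2 to compound 3 (0.09 log units; within the scatter), shows that adding a methyl at that place left the read-out unchanged within scatter.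

Compound 4, `CCOC(=O)N(C)CC#CCN1CCCC1`, has not yet been measured. It differs from compound 1 by methyl in place of hydrogen on a saturated chain carbon bound to an oxygen next to a carbonyl group. This is the same kind of change as from compound 2 to compound 3, a methyl entering for a hydrogen, but the place is not the same: on a saturated chain carbon bound to an oxygen next to a carbonyl group rather than on a saturated chain carbon bound to an amide-type nitrogen and a triple-bonded carbon.

Resting on the small step of a 1.2-fold higher number from compound 2 to compound 3 (0.09 log units; within the scatter), the expected step that the limit leaves unreadable from compound 1 to compound 4 is taken to be small as well. Since compound 1 reaches only a limit in this assay, compound 4 is estimated at 15 mg/kg, with a range from 7 mg/kg to 40 mg/kg, and it is expected that the assay may again report only a limit for compound 4.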

Compound 4, dose for half-maximal effect: > 100 mg/kg
Compound 4: a limit, no number; the forecaster's own chance of this, stated with the estimate: 65%; middle value at least 6.6-fold (0.82 log units) from the limit.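

In this assay compound 1 gives only a limit of the assay (> 10 mg/kg) and no number. Among the compounds shown here, compound 4 likewise gives only a limit (> 100 mg/kg) and no number, so no step between compound 1 and compound 4 can be read. The compounds shown leave open what number either compound would reach, and whether methyl in place of hydrogen at this place changes the read-out at all.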